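This account rests on a few compounds, and the source may have more. Where it says the series, first, only, none or still open, it means among the compounds named here.

Measured in a functional assay on HT-29 cells (Homo sapiens) for inhibition, read by sulforhodamine B assay, with a stated time of 48 h; on this read-out lower numbers stand for stronger inhibition and higher numbers for weaker inhibition:
- compound 1 `CCNC(=O)Nc1ccc(/C=C\c2cc(C)cc(C)c2)cc1` - 11000 nM
- compound 2 `Cc1cc(C)cc(/C=C/c2ccc(N3CCNC3=O)cc2)c1` - 14000 nM

Compound 1 at 11000 nM and compound 2 at 14000 nM lie within the scatter of each other, so the numbers do not separate them. Among the compounds with values here, compound 2 therefore stands level with the only other measured compound.

The next compound is compound 3 `CCNC(=O)Nc1ccc(/C=C/c2cc(C)cc(C)c2)cc1`, where (ethylcarbamoyl)amino stands in place of 2-oxoimidazolidin-1-yl on an aromatic carbon, para to a large group: (ethylcarbamoyl)amino in place of 2-oxoimidazolidin-1-yl on an aromatic carbon. Within the data shown here, no measured pair shows this exchange, so the data give no direct guide to its size. In this assay no step beyond the scatter is expected, in either direction. The estimated change is a 1.2-fold lower number from compound 2 to compound 3 (0.07 log units; within the scatter), which is expected to stay within the scatter. Compound 3 is estimated at 12000 nM, with an expected range from 4000 nM to 40000 nM.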

Compound 3, half-maximal inhibitory concentration: > 20000 nM
Compound 3: only a limit was reported (the forecaster's own chance of this, stated with the estimate: 15%); at least 1.6-fold (0.22 log units) between middle value and limit.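

In this assay compound 3 gives > 20000 nM, a limit of the assay and not a number. At this position, on an aromatic carbon para to a large group, (ethylcarbamoyl)amino in place of 2-oxoimidazolidin-1-yl gives an at least 1.4-fold higher number from compound 2 to compound 3 (0.15 log units; that floor lies within the scatter), so the exchange shows no gain in inhibition, while its true size stays unresolved. Compound 3 also adds a comparison of drawn configuration, E against Z, with an at least 1.8-fold higher number from compound 1 to compound 3 (0.25 log units; that floor lies within the scatter), a floor that can be read on this one feature alone: the fact that compounds 1 and 3 differ only in the configuration as drawn

On these data alone, whether compound 3 truly lies beyond the scatter from compound 1 or compound 2 stays open with only a limit to go on. Also open, as far as these compounds go, is how a carboxylic acid or an amine at this position, or a longer chain in place of ethyl, would read in this assay.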